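This account rests on a few compounds, and the source may have more. Where it says the series, first, only, none or still open, it means among the compounds named here.

Measured in a functional assay on ACHN cells (Homo sapiens); a higher number here means a weaker inhibitor of growth, a lower number a stronger inhibitor of growth:
- compound 1 `N#Cc1ccc(/C=C/S(=O)(=O)Cc2ccc(Nc3ncnc4ccccc34)cc2)cc1`: > 100000 nM, a limit of the assay
- compound 2 `O=S(=O)(/C=C/c1ccc(Br)cc1)Cc1ccc(Nc2ncnc3ccccc23)cc1`: 200 nM
- compound 3 `O=S(=O)(/C=C/c1ccc(F)cc1F)Cc1ccc(Nc2ncnc3ccccc23)cc1`: 31000 nM

Within the data shown here, of the two exact numbers, the one for compound 3 is the higher, and the gap to its only exact neighbour is large: a 160-fold higher number from compound 2 to compound 3 (2.19 log units; beyond the scatter). Since compound 1 gives only a limit, an at least 3.2-fold lower number from compound 1 to compound 3 (0.50 log units; beyond the scatter) is a bound and not a size.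

Compound 4 `O=S(=O)(/C=C/c1ccc(F)cc1Cl)Cc1ccc(Nc2ncnc3ccccc23)cc1` has not yet been measured. Its difference is chloro in place of fluoro on an aromatic carbon, ortho to a large group and meta to a fluoro group.

Among the measured compounds shown here, no measured step makes this exchange alone. The closest are a 160-fold higher number from compound 2 to compound 3 (2.19 log units; beyond the scatter) and an at least 500-fold lower number from compound 1 to compound 2 (2.69 log units; beyond the scatter), both large, but each replaces a different substituent pattern on the same aromatic ring. They show that this ring can move the number strongly. For the measured compounds named here, compound 2, the only measured compound carrying a halogen other than fluoro, gives 200 nM, so the expected direction is towards a lower number, though one exchange on compound 3 need not cover the whole gap.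

The expected move in this assay is a 5.2-fold lower number from compound 3 to compound 4 (0.71 log units; beyond the scatter), which is an estimate of moderate size. For compound 4 the estimated value is 6000 nM, with an expected range of 800 nM to 40000 nM.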

Compound 4, concentration for 50% growth inhibition: 73000 nM
The estimate for compound 4 lay 12-fold (1.09 log units) below the measured number; measured number outside the range, above it.
By their numbers in this assay, from the lowest: compound 2; then compound 3; then compound 4. At a limit, above all of these: compound 1.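

In this assay, chloro in place of fluoro on an aromatic carbon, ortho to a large group and meta to a fluoro group, gives a 2.4-fold higher number from compound 3 to compound 4 (0.37 log units; beyond the scatter), a modest move that takes the number further from compound 2 rather than towards it. Having a halogen other than fluoro on this ring is therefore not enough to reach the low number of the 4-bromophenyl compound, as a 370-fold higher number from compound 2 to compound 4 (2.56 log units; beyond the scatter) shows, and 2-chloro-4-fluorophenyl stays in the same high region as 2,4-difluorophenyl. The remaining step, an at least 1.3-fold lower number from compound 1 to compound 4 (0.13 log units; that floor lies within the scatter), cannot be read, since it starts from a limit: the limit of > 100000 nM in this assay, at which 1 of the 4 values shown sits.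

Open, as far as these compounds go, is whether the low number of compound 2 goes with the bromo itself or with the ring carrying nothing ortho to a large group, as 4-bromophenyl differs from both 2,4-difluorophenyl and 2-chloro-4-fluorophenyl in two places at once. A 4-chlorophenyl group, or a methoxy or an amine at the place ortho to a large group, would separate these readings.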